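Chalcone ethers against NF-kappa-B: a cyclopentyl-to-cyclohexylmethyl step

A few compounds are considered here, and "the series" means these few. Any claim that something is new, unique, unknown or untested is made for them only; others in the source may bear on it.

Compound 1, `COc1cccc(OCCC(C)(C)C)c1C(=O)/C=C/c1ccc(O)cc1`: > 30000 nM
Compound 2, `O=C(/C=C/c1ccc(O)cc1)c1c(O)cccc1OCC1CCCC1`: 13000 nM

In an assay on THP-1 cells for inhibition of nuclear factor NF-kappa-B complex (Homo sapiens), with stated times of 2 h and 16 h (on this read-out lower numbers stand for stronger inhibition and higher numbers for weaker inhibition), compound 1 gives only a limit, > 30000 nM, at the edge of what the assay reports (the limit of > 30000 nM in this assay, at which 1 of the 2 values shown sits). Going by the values given here, compound 2 is the one compound with a number, giving 13000 nM in this assay, so it stands alone among the values shown. Compound 3, `O=C(/C=C/c1ccc(O)cc1)c1c(O)cccc1OCCC1CCCCC1`, has not been measured in this assay. It differs from compound 2 by cyclohexylmethyl in place of cyclopentyl on a saturated chain carbon bound to an oxygen on an aromatic ring. Among the compounds with values here, no measured step exists to set the size of this change, so compound 3 is expected to land close to compound 2, with the step from compound 2 to compound 3 estimated as a 1.3-fold lower number from compound 2 to compound 3 (0.11 log units; within the scatter), not beyond the usual scatter. Compound 3 is therefore estimated at 10000 nM in this assay, within 3000 nM to 30000 nM.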

Compound 3, half-maximal inhibitory concentration: > 30000 nM
Compound 3 was reported as a limit; the forecaster's own chance of this, stated with the estimate: 25%; middle value at least 3.0-fold (0.47 log units) from the limit.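

At the saturated chain carbon bound to an oxygen on an aromatic ring, the change from cyclopentyl to cyclohexylmethyl is not neutral: it gives an at least 2.3-fold higher number from compound 2 to compound 3 (0.36 log units; beyond the scatter) in this assay. Compound 3 gives only a limit, so this step has a lower bound and no exact size. Compound 2 remains the only compound with a number: the limit of > 30000 nM in this assay, at which 2 of the 3 values shown sit.

Going by these compounds, this step changes ring size and chain length at once, and their separate contributions remain open. So does whether an amine or a carboxylic acid on the ring would lower the number.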